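The compounds below may be only part of what the source reports. "The series", "measured", "known", "first", "only" and "open" are said of these compounds alone.

Compound 1 `CCn1c(C(=O)NCCCN(C)C)ccc1C(CC)(CC)c1ccc(OCCC(O)(CC)CC)c(C)c1` gives 3350 nM in a functional assay on MCF7 cells (Homo sapiens) for antiproliferative activity, read by MTT assay, with a stated time of 48 h (a lower number here means a stronger inhibitor, a higher number a weaker inhibitor), the higher of the two numbers that stand beside it, though compound 3 `CCOC(=O)CN(C)C(=O)c1ccc(C(CC)(CC)c2ccc(OCCC(O)(CC)CC)c(C)c2)n1CC` gives 3210 nM, a step of a 1.0-fold lower number from compound 1 to compound 3 (0.02 log units; within the scatter). Compound 2 `C#CCCOC(=O)c1ccc(C(CC)(CC)c2ccc(OCCC(O)(CC)CC)c(C)c2)n1CC` reaches only a limit of this assay, > 50000 nM, as the limit of > 50000 nM in this assay, at which 1 of the 3 values shown sits, records. The steps involving it are an at least 14-fold higher number from compound 1 to compound 2 (1.17 log units; beyond the scatter) and an at least 15-fold lower number from compound 2 to compound 3 (1.19 log units; beyond the scatter). Compound 4 `CCC(C)C(NC(=O)c1ccc(C(CC)(CC)c2ccc(OCCC(O)(CC)CC)c(C)c2)n1CC)C(=O)O` differs from compound 1 in that (1-carboxy-2-methylbutyl in place of 3-(dimethylamino)propyl on an amide-type nitrogen). The amide-type nitrogen is retained, as in the step to compound 3 that stayed within the scatter, whereas the large losses arose only where (but-3-yn-1-yl)oxy replaced the amino group on the carbonyl carbon. Compound 4 is therefore expected to show a 1.6-fold higher number from compound 1 to compound 4 (0.22 log units; within the scatter), with an estimated 5500 nM, between 2000 nM and 25000 nM.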

Compound 4, half-maximal inhibitory concentration: 11300 nM
The estimate for compound 4 lay 2.1-fold (0.31 log units) below the measured number, and the stated range covers the measured number.
By their numbers in this assay, from the lowest: compounds 3 and 1 (each within the scatter of the next); then compound 4. At a limit, above all of these: compound 2.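

On the amide-type nitrogen, 1-carboxy-2-methylbutyl, unlike ((ethoxycarbonyl)methyl)(methyl)amino on the carbonyl carbon, shifts the result in this assay beyond the scatter, with a 3.4-fold higher number from compound 1 to compound 4 (0.53 log units; beyond the scatter) and a 3.5-fold higher number from compound 3 to compound 4 (0.55 log units; beyond the scatter); keeping that nitrogen therefore does not by itself hold the number level. Replacing (but-3-yn-1-yl)oxy with (1-carboxy-2-methylbutyl)amino still gives an at least 4.4-fold lower number from compound 2 to compound 4 (0.64 log units; beyond the scatter). Compound 2 supplies only a limit, so that step is a bound: the limit of > 50000 nM in this assay, at which 1 of the 4 values shown sits.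

Going by these compounds, it remains open whether the carboxylic acid or the branched chain accounts for the shift. An ethyl ester of that acid, or an unbranched carboxyalkyl chain, would bear on this.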